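Aryl swap on the ring nitrogen: outlook for compound 4

The source may report more compounds than this note shows. Statements on the series, on what has been measured and on what is new or still open speak of the compounds shown alone.

Compound 1 `Nc1scc(CN2CCN(c3cc(Cl)cc(Cl)c3)CC2)c1C(=O)c1ccc(Cl)cc1` carries a 3,5-dichlorophenyl on an amine nitrogen in a ring; in an assay on CHO cells for displacement of a labelled ligand from adenosine receptor A3 (Homo sapiens), read by scintillation counting, with a stated time of 120 min, tested at 10 uM (on this read-out lower numbers stand for less inhibition and higher numbers for more inhibition at the one concentration tested (going by the name of the read-out)), compound 1 gives 1%. Compound 2 `Nc1scc(CN2CCN(c3ccc(F)cc3Cl)CC2)c1C(=O)c1ccc(Cl)cc1` carries 2-chloro-4-fluorophenyl at that place, and in this assay compound 2 gives 0%. Compound 3 `Nc1scc(CN2CCN(c3ccc(OC(F)(F)F)cc3)CC2)c1C(=O)c1ccc(Cl)cc1` carries 4-(trifluoromethoxy)phenyl there, and in this assay compound 3 gives 1%. Compound 1 stands level with compound 3 at the digits shown, the two together the highest of these three numbers, and compound 2 is the furthest from compound 1. The measured steps are a number 1 percentage points lower from compound 1 to compound 2 (within the scatter), no change at the digits printed from compound 1 to compound 3 (within the scatter) and a number 1 percentage points higher from compound 2 to compound 3 (within the scatter), each within the scatter, so the three aryl variants are not told apart in this assay.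

Compound 4 `Nc1scc(CN2CCN(c3ccc(F)c(F)c3)CC2)c1C(=O)c1ccc(Cl)cc1` has not yet been measured. It differs from compound 1 as follows: 3,4-difluorophenyl in place of 3,5-dichlorophenyl on an amine nitrogen in a ring. The change sits at the same place as the three measured steps, all of which stayed within the scatter, so no step beyond the scatter is expected in this assay; the expected step is no change at the digits printed from compound 1 to compound 4 (within the scatter). For compound 4 the estimated value in this assay is 1%, with an expected range from -8% to 10%.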

Compound 4, a percentage reported as inhibition, at one concentration (the size of the read-out at that concentration, not a potency): 1%
Estimate against measurement, compound 4: no gap at the digits printed; the range from low to high includes it.
By their numbers in this assay, from the lowest: compounds 2, 1, 3 and 4 (each within the scatter of the next).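

With 3,4-difluorophenyl on the ring nitrogen, this assay gives no change at the digits printed from compound 1 to compound 4 (within the scatter) and no change at the digits printed from compound 3 to compound 4 (within the scatter) along with a number 1 percentage points higher from compound 2 to compound 4 (within the scatter) in this fourth aryl variant. The series now includes a swap of both chlorines for fluorines at an unchanged count of heavy atoms, with no hydrogen-bond donors or acceptors on either group, and the chlorine-free 3,4-difluorophenyl is not told apart from the three earlier aryl groups at this place, so the flat result extends beyond the chlorine-bearing pair and the 4-(trifluoromethoxy)phenyl group. No available data bear on why the read-out stays flat across these four compounds.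

The compounds shown leave open whether an aryl group carrying a carboxylic acid, a hydroxyl or an amine, or a saturated cyclohexyl group in place of the aryl ring, would move the read-out at this position. They also leave open whether any change elsewhere on the shared core, such as replacing the free amine with an acetamide, would give a number beyond the scatter.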